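This account rests on a few compounds, and the source may have more. Where it says the series, first, only, none or still open, it means among the compounds named here.

Among the measured compounds shown here, in a physicochemical assay for lipophilicity, at pH 7.4 (on this read-out higher numbers stand for higher lipophilicity and lower numbers for lower lipophilicity), compound 1 `CC(C)CN(Cc1ccccc1C(F)(F)F)S(=O)(=O)c1ccc2c(c1)C(O)CC(C1CCOCC1)O2` gives 4.23, the lowest of the three values so far. Compound 2 `CCc1ccc(N(CC(C)C)S(=O)(=O)c2ccc3c(c2)C(O)CC(C(C)C2CCOCC2)O3)cc1` gives 5.04, the nearest to compound 1 and beyond the scatter above it. Compound 3 `CCc1ccc(N(CC(C)C)S(=O)(=O)c2ccc3c(c2)C(C)CC(C2CCOCC2)O3)cc1` gives 5.71, the furthest from compound 1 and likewise beyond the scatter. Compounds 2 and 3 each differ from compound 1 in more than one place, so no single change is isolated among the measured compounds. Compound 4 `CC(C)CN(c1ccc(F)cc1F)S(=O)(=O)c1ccc2c(c1)C(O)CC(C1CCOCC1)O2` is still to be measured in this assay. It differs from compound 1 in one place: 2,4-difluorophenyl in place of 2-(trifluoromethyl)benzyl on a sulfonamide nitrogen. The group that leaves is a benzyl carrying a trifluoromethyl; the group that enters is a phenyl carrying two fluorines, and it is the smaller of the two. For the measured compounds named here, with no measured step of this kind to lean on, the expectation rests on the change alone. Compound 4 is expected to read lower than compound 1 in this assay, by a step of a number 0.83 log units lower from compound 1 to compound 4 (beyond the scatter), beyond the scatter. The estimate for compound 4 is 3.4, with a range from 2.8 to 4.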

Compound 4, distribution coefficient: 3.53
Beside the measured number, compound 4's estimate is 0.13 log units below it; the measured number falls inside the stated range.
By their numbers in this assay, from the lowest: compound 4; then compound 1; then compound 2; then compound 3.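

Among the compounds shown here, the first isolated step lies on the sulfonamide nitrogen: in this assay, 2,4-difluorophenyl in place of 2-(trifluoromethyl)benzyl gives a number 0.70 log units lower from compound 1 to compound 4 (beyond the scatter) with the rest of compound 1 unchanged. The read-out therefore moves beyond the scatter with this substituent alone, which compounds 2 and 3, each differing from compound 1 in more than one place, could not show. No measurement in hand bears on the reason for this step.

The exchange alters the benzyl link and the ring substituents together, so their separate shares remain unresolved. A 2,4-difluorobenzyl or a 2-(trifluoromethyl)phenyl group on the same nitrogen would separate them, and an unsubstituted benzyl would show the contribution of the trifluoromethyl group.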